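Ester variant of the furyl dihydropyrimidinone series

The compounds below may be only part of what the source reports. "The series", "measured", "known", "first", "only" and "open" are said of these compounds alone.

Compound 1 `CCNC(=O)C1=C(C)NC(=O)NC1c1ccco1` and compound 2 `CCSC(=O)C1=C(C)NC(=O)NC1c1ccco1` share one core. In an assay on membranes from CHO cells for displacement of a labelled ligand from adenosine receptor A1 (Homo sapiens), read by scintillation counting, with a stated time of 60 min, tested at 1 uM (on this read-out higher numbers stand for more inhibition at the one concentration tested (going by the name of the read-out) and lower numbers for less inhibition), compound 1 gives 2% and compound 2 gives 6%. Compound 2 holds the higher of the two numbers, though a number 4 percentage points higher from compound 1 to compound 2 (within the scatter) leaves the pair within the scatter. Compound 3 `CC1=C(C(=O)OC2CCCC2)C(c2ccco2)NC(=O)N1` arises from compound 2 by cyclopentyloxy in place of ethylsulfanyl on a carbonyl carbon. Among the measured compounds shown here, only the step from compound 1 to compound 2 is known, and it changed a different group at the same carbonyl carbon without moving the number beyond the scatter; no step with a cyclopentyloxy group is known. Compound 3 is therefore expected to show no change beyond the scatter, a number 1 percentage points lower from compound 2 to compound 3 (within the scatter), with an estimate of 5% in a range of -5% to 18%.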

Compound 3, a percentage reported as inhibition, at one concentration (the size of the read-out at that concentration, not a potency): 1%
Compound 3: middle estimate off by 4 percentage points, on the high side, and the stated range covers the measured number.
By their numbers in this assay, from the lowest: compounds 3, 1 and 2 (each within the scatter of the next).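

Among the compounds shown here, the steps of a number 5 percentage points lower from compound 2 to compound 3 (within the scatter) and a number 1 percentage points lower from compound 1 to compound 3 (within the scatter) in this assay show that cyclopentyloxy, the first group here with a ring on this carbonyl carbon, stays within the scatter of both ethylsulfanyl and ethylamino. The three groups at this carbonyl carbon therefore cannot be told apart on this read-out. No supporting evidence bears on this result. Going by these compounds, whether a carboxylic acid, an amine or a longer chain on this carbonyl carbon would move the number beyond the scatter remains open.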